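Pyrrolidinyl to piperidinyl amide on the shared core

A few compounds are considered here, and "the series" means these few. Any claim that something is new, unique, unknown or untested is made for them only; others in the source may bear on it.

Measured so far:
compound 1 `Cc1cc(C(=O)N2CCCCc3ccccc32)ccc1CNC(=O)NCC(=O)O`: 180 nM
compound 2 `Cc1cc(C(=O)N2CCCCc3ccccc32)ccc1CNC(=O)NCC(=O)N1CCCC1`: 100 nM

In a functional assay on HEK293 cells for agonist activity at Vasopressin V2 receptor (Homo sapiens), read by a luciferase reporter and cAMP accumulation (a higher number here means that more compound is needed for the effect, a lower number that less compound is needed), compound 1 gives 180 nM. Compound 2 gives 100 nM. For the measured compounds named here, compound 2 stands at the low end of the two numbers, but the only step so far, a 1.8-fold lower number from compound 1 to compound 2 (0.26 log units; within the scatter), lies within the scatter, so compound 1 and compound 2 are not separated by these data.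

Compound 3 `Cc1cc(C(=O)N2CCCCc3ccccc32)ccc1CNC(=O)NCC(=O)N1CCCCC1` differs from compound 2 by piperidin-1-yl in place of pyrrolidin-1-yl on a carbonyl carbon. Going by the values given here, the one measured step bears on it only loosely: it altered the group on the same carbonyl carbon, pyrrolidin-1-yl in place of hydroxy, and stayed within the scatter. Among the compounds with values here, no measured pair exchanges one ring for another, so there is no direct precedent; on what is known, no step beyond the scatter is expected in this assay.

Compound 3 is therefore estimated at 100 nM, with a range of 40 nM to 250 nM. The expected step is no change at the digits printed from compound 2 to compound 3 (within the scatter).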

Compound 3, half-maximal effective concentration: 150 nM
Compound 3: middle estimate off by 1.5-fold (0.18 log units), on the low side, within the range that was stated.
By their numbers in this assay, from the lowest: compounds 2, 3 and 1 (each within the scatter of the next).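

On the carbonyl carbon, the exchange of pyrrolidin-1-yl for the larger ring piperidin-1-yl gives a 1.5-fold higher number from compound 2 to compound 3 (0.18 log units; within the scatter) in this assay, so these data do not separate the five-membered and six-membered rings. Set against the hydroxy compound, the piperidine amide gives a 1.2-fold lower number from compound 1 to compound 3 (0.08 log units; within the scatter), so this position has now carried hydroxy and two cyclic amine groups with no listed step beyond the scatter, and compounds 1, 2 and 3 remain unseparated. No other measurement accompanies these numbers, so nothing bears on what lies behind them.

As far as these compounds go, it remains open whether an open-chain dimethylamino group, a morpholin-4-yl ring or a plain amino group on the same carbonyl carbon would give a step beyond the scatter. From the compounds shown here alone, a longer chain leading to that carbonyl is equally open.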